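The source may report more compounds than this note shows. Statements on the series, on what has been measured and on what is new or still open speak of the compounds shown alone.

In a functional assay on the whole organism for antagonist activity, with Mus musculus as the target (on this read-out lower numbers stand for an effect already at smaller amounts and higher numbers for an effect only at larger amounts of compound), compound 2 `COC(=O)N(C)C(C)C#CCn1ccnc1` gives > 100 mg/kg, which is a limit of the assay and not a number. Compound 2 therefore stands at the end of the scale: the limit of > 100 mg/kg in this assay, at which 1 of the 2 values shown sits. Compound 1 `CC(=O)N(C)C(C)C#CCn1cncc1C` gives a true number, 3.7 mg/kg. Compound 3 `COC(=O)N(C)C(C)C#CCn1cncc1C` is compound 2 with a single change, methyl in place of hydrogen on an aromatic carbon. Going by the values given here, compound 1 carries this methyl too but differs from compound 3 elsewhere, and no measured pair isolates the change. In this assay a step beyond the scatter toward smaller doses is expected, resting only on compound 1 at 3.7 mg/kg. The expected step is an at least 6.6-fold lower number from compound 2 to compound 3 (0.82 log units; beyond the scatter). For compound 3 the estimated value is 15 mg/kg, with an expected range of 4 mg/kg to 80 mg/kg.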

Compound 3, dose for half-maximal effect: 6.6 mg/kg
Estimate against measurement, compound 3: 2.3-fold (0.36 log units) above; the measured number falls inside the stated range.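

In this assay, the pair isolates methyl in place of hydrogen on an aromatic carbon, next to the ring nitrogen and next to the ring atom that bears a large group, and gives an at least 15-fold lower number from compound 2 to compound 3 (1.18 log units; beyond the scatter). This step is a bound and not an exact size, as compound 2 stands at a limit: the limit of > 100 mg/kg in this assay, at which 1 of the 3 values shown sits. With this methyl present, methoxy in place of methyl on a carbonyl carbon gives a 1.8-fold higher number from compound 1 to compound 3 (0.25 log units; within the scatter), so the two carbonyl groups are not separated in this read-out.

The methyl step is read only with the methoxy on the carbonyl, as the compounds shown include no partner of compound 1 with hydrogen on this ring carbon. As far as these compounds go, how ethyl or chlorine would compare with methyl on this ring carbon remains open.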